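This account rests on a few compounds, and the source may have more. Where it says the series, first, only, none or still open, it means among the compounds named here.

Measured so far:
- compound 1 `CC(C(=O)NCc1ccc(C(F)(F)F)nc1NCc1ccc(Cl)cc1)c1ccc(NS(C)(=O)=O)c(F)c1`: 65.7 nM
- compound 2 `C[C@H](C(=O)NCc1ccc(C(F)(F)F)nc1N1CC[C@H](N(C)C)C1)c1ccc(NS(C)(=O)=O)c(F)c1`: 103 nM

In a functional assay on CHO-K1 cells for antagonist activity at transient receptor potential cation channel subfamily V member 1 (Homo sapiens), read by FLIPR (on this read-out lower numbers stand for stronger inhibition and higher numbers for weaker inhibition), compound 1 gives 65.7 nM, the lower of the two numbers, and compound 2 gives 103 nM; the gap between them is within the scatter, so the two cannot be ranked. Both share the same core, differing only in the group that sits next to the ring nitrogen of the trifluoromethyl-bearing ring.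

Compound 3 `CC(C(=O)NCc1ccc(C(F)(F)F)nc1N1CCC(O)CC1)c1ccc(NS(C)(=O)=O)c(F)c1` has not yet been measured. It differs from compound 1 in one place: 4-hydroxypiperidin-1-yl in place of (4-chlorobenzyl)amino on an aromatic carbon. Compound 2 shows that a cyclic amine at this position is tolerated, as its value 103 nM sits within the scatter of compound 1.

Within the data shown here, no measured pair directly mirrors this change, so the step from compound 1 to compound 3 is estimated to be small, perhaps a slight weakening, at a 1.8-fold higher number from compound 1 to compound 3 (0.26 log units; within the scatter). Compound 3 is expected to give 120 nM in this assay, with a range from 40 nM to 400 nM.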

Compound 3, inhibition constant: "not active" (no number reported)
No number was reported for compound 3; the estimate stays without a comparison.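

Among these compounds, compound 3 is reported in this assay only as "not active", without a number, so no step from compound 1 to compound 3 can be read. How far compound 3 lies from compound 1 stays open, and nothing shown here explains the result.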